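The source may hold more compounds than are shown below. What is called first, only, known or untested is meant among the compounds shown, and "the series" means these compounds.

For the measured compounds named here, compound 1 `O=C(O)CCC/C=C1\C[C@H]2CC[C@H](/C=N/NC(=O)Nc3cccc(Cl)c3)[C@H]2C1` gives 6500 nM in a functional assay on a cell-free system (plasma) for agonist activity at thromboxane A2 receptor (Homo sapiens) (on this read-out lower numbers stand for stronger inhibition and higher numbers for weaker inhibition), the highest of the three numbers so far; compound 2 `O=C(O)COC/C=C1\C[C@H]2C[C@@H](O)[C@H](/C=N/NC(=O)Nc3ccc(Cl)c(Cl)c3)[C@H]2C1` gives 180 nM and compound 3 `O=C(O)COC/C=C1\C[C@H]2C[C@@H](O)[C@H](/C=N/NC(=O)Nc3ccc([N+](=O)[O-])cc3)[C@H]2C1` gives 190 nM, both on a core unlike that of compound 1. Compound 4 `O=C(O)CCC/C=C1\C[C@H]2CC[C@H](/C=N/NC(=O)Nc3ccc([N+](=O)[O-])cc3)[C@H]2C1` differs from compound 1 in one place: 4-nitrophenyl in place of 3-chlorophenyl on an amide-type nitrogen. Going by the values given here, the only measured step bearing on this is a 1.1-fold higher number from compound 2 to compound 3 (0.02 log units; within the scatter), which puts 4-nitrophenyl in place of 3,4-dichlorophenyl on the other core and stays within the scatter. The leaving group there is not the same as in compound 1, so the transfer is loose. Compound 4 is expected to give about 5000 nM (range 1500 nM to 16000 nM), an expected step of a 1.3-fold lower number from compound 1 to compound 4 (0.11 log units; within the scatter).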

Compound 4, half-maximal inhibitory concentration: 1700 nM
The estimate for compound 4 lay 2.9-fold (0.47 log units) above the measured number; measured number inside the range.
By their numbers in this assay, from the lowest: compounds 2 and 3 (each within the scatter of the next); then compound 4; then compound 1.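

On the core of compound 1, the group on the amide-type nitrogen does move the number in this assay with a 3.8-fold lower number from compound 1 to compound 4 (0.58 log units; beyond the scatter) on going to 4-nitrophenyl. The earlier step at this place, a 1.1-fold higher number from compound 2 to compound 3 (0.02 log units; within the scatter) on another core, started from 3,4-dichlorophenyl, so the two steps are not a matched pair. Nothing measured here accounts for the step.

As far as these compounds go, whether the shift follows from the loss of 3-chlorophenyl or the entry of 4-nitrophenyl stays open. A plain phenyl group on the same nitrogen of this core would separate the two.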